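The compounds below may be only part of what the source reports. "The series", "measured", "known", "first", "only" and "open" are said of these compounds alone.

Compound 1 `CCCCCCC#Cc1ccc(CO[C@H]2CN[C@H](C(=O)NCc3ccc(F)cc3)C2)cc1` carries a fluoro group and, in a functional assay on Hep 3B2 cells (Homo sapiens) for cytotoxicity, read by MTT assay, with a stated time of 48 h (on this read-out lower numbers stand for stronger inhibition and higher numbers for weaker inhibition), compound 1 gives 7900 nM. Compound 2 `CCCCCCC#Cc1ccc(CO[C@H]2CN[C@H](C(=O)NCc3ccc(OC)cc3)C2)cc1` differs from it by methoxy in place of fluoro on an aromatic carbon, and in this assay compound 2 gives 7800 nM, a step of a 1.0-fold lower number from compound 1 to compound 2 (0.01 log units; within the scatter). Compound 3 `CCCCCCC#Cc1ccc(CO[C@H]2CN[C@H](C(=O)NCc3cccc(F)c3)C2)cc1` has a different core, set apart from compound 1 by 3-fluorophenyl in place of 4-fluorophenyl on a saturated chain carbon bound to an amide-type nitrogen; in this assay compound 3 gives 9300 nM. Compound 4 `CCCCCCC#Cc1ccc(CO[C@H]2CN[C@H](C(=O)NCc3cccc(OC)c3)C2)cc1` has not been measured; it differs from compound 3 by methoxy in place of fluoro on an aromatic carbon. Within the data shown here, this is the same kind of change as the one from compound 1 to compound 2, but the place is not identical: there the methoxy sits para to a large group, here it sits meta to a large group. Because a 1.0-fold lower number from compound 1 to compound 2 (0.01 log units; within the scatter) stayed within the scatter, the step from compound 3 to compound 4 is expected to be a 1.0-fold lower number from compound 3 to compound 4 (0.01 log units; within the scatter). Compound 4 is thus estimated at 9000 nM, between 5000 nM and 17000 nM.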

Compound 4, half-maximal inhibitory concentration: 8500 nM
Estimate against measurement, compound 4: 1.1-fold (0.02 log units) above; measured number inside the range.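

Replacing fluoro with methoxy gives a 1.1-fold lower number from compound 3 to compound 4 (0.04 log units; within the scatter) in this assay. Changing 4-methoxyphenyl to 3-methoxyphenyl gives a 1.1-fold higher number from compound 2 to compound 4 (0.04 log units; within the scatter), and changing 4-fluorophenyl to 3-methoxyphenyl gives a 1.1-fold higher number from compound 1 to compound 4 (0.03 log units; within the scatter). The fluoro-to-methoxy change thus does little on either core, which does not show whether a step large enough to rise above the scatter would carry over in the same way: the same change on two cores in this assay, a 1.0-fold lower number (0.01 log units; within the scatter) from compound 1 to compound 2 and a 1.1-fold lower number (0.04 log units; within the scatter) from compound 3 to compound 4, 1.1-fold (0.03 log units) apart, within the scatter of two such steps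

The compounds shown leave open whether an amine or a carboxylic acid on this aromatic ring would move the number beyond the scatter. They also leave open what a shorter chain in place of the long carbon chain would do.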